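This account rests on a few compounds, and the source may have more. Where it says the series, first, only, none or still open, it means among the compounds named here.

In a functional assay on SK-BR-3 cells (Homo sapiens) for antiproliferative activity (a higher number here means a weaker inhibitor, a lower number a stronger inhibitor), compound 3 `CC(C)=CCc1cc(C(=O)Nc2cc3ccc(OCCCNCCO)c(C)c3oc2=O)ccc1O` gives 610 nM. Compound 1 `CCN(C)CCCOc1ccc2cc(NC(=O)c3ccc(O)c(CC=C(C)C)c3)c(=O)oc2c1C` gives 730 nM, and these two values sit together: a 1.2-fold lower number from compound 1 to compound 3 (0.08 log units; within the scatter). Compound 2 `CCCN(CCC)CCCOc1ccc2cc(NC(=O)c3ccc(O)c(CC=C(C)C)c3)c(=O)oc2c1C` reaches only a limit of the assay, > 50000 nM. Compound 4 `CC(C)=CCc1cc(C(=O)Nc2cc3ccc(OCCCN(C)C4CCCCC4)c(C)c3oc2=O)ccc1O` carries this change: cyclohexyl(methyl)amino in place of (2-hydroxyethyl)amino on a saturated chain carbon, three bonds along the chain from an oxygen on an aromatic ring. Cyclohexyl(methyl)amino thus replaces (2-hydroxyethyl)amino on the same chain. The measured amine swaps at this place bear on it, and two are large: an at least 68-fold higher number from compound 1 to compound 2 (1.83 log units; beyond the scatter), and an at least 81-fold lower number from compound 2 to compound 3 (1.91 log units; beyond the scatter). The entering group is large, like the dipropylamino group of compound 2, so a clear loss is expected, though probably a smaller one. The expected change is a 4.9-fold higher number from compound 3 to compound 4 (0.69 log units; beyond the scatter). The estimate for compound 4 is 3000 nM, with an expected range of 400 nM to 40000 nM.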

Compound 4, half-maximal inhibitory concentration: 970 nM
For compound 4 the middle estimate is 3.1-fold (0.49 log units) above the measured one, and the stated range covers the measured number.
By their numbers in this assay, from the lowest: compounds 3, 1 and 4 (each within the scatter of the next). At a limit, above all of these: compound 2.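

In this assay, cyclohexyl(methyl)amino at this place stays level with the smaller amines: a 1.6-fold higher number from compound 3 to compound 4 (0.20 log units; within the scatter), and a 1.3-fold higher number from compound 1 to compound 4 (0.12 log units; within the scatter). The step from dipropylamino is large, an at least 51-fold lower number from compound 2 to compound 4 (1.71 log units; beyond the scatter), so a ring-bearing amine without a hydrogen-bond donor need not bring the loss seen with compound 2. Compound 2 stands at a limit of the assay, not at a number: the limit of > 50000 nM in this assay, at which 1 of the 4 values shown sits.

On these data alone, what sets dipropylamino apart from these amines stays open. So does whether a morpholine, a piperazine or a longer chain would keep values of this order.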